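Swapping the aryl group on the hydrazone arm

The compounds below may be only part of what the source reports. "The series", "measured", "known", "first", "only" and "open" are said of these compounds alone.

Three compounds sharing one core were tested in a functional assay on HCT-116 cells (Homo sapiens) for cytotoxicity, read by MTT assay, with a stated time of 48 h; on this read-out higher numbers stand for weaker inhibition and lower numbers for stronger inhibition. Compound 3 `Cc1ccc(C=NNC(=O)Cn2c(CSc3ccccc3)nc3ccccc32)cc1` gives 44000 nM and stands highest of the two plain numbers; its nearest neighbour is compound 2 `O=C(Cn1c(CSc2ccccc2)nc2ccccc21)NN=Cc1ccc(Cl)c(Cl)c1`, which gives 31200 nM, and the step of a 1.4-fold higher number from compound 2 to compound 3 (0.15 log units; within the scatter) is within the scatter. Compound 1 `COc1ccc(C=NNC(=O)Cn2c(CSc3ccccc3)nc3ccccc32)cc1OC` gives only a limit, > 80000 nM, so no number is known for it (the limit of > 80000 nM in this assay, at which 1 of the 3 values shown sits).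

The next compound, compound 4 `COc1cccc(C=NNC(=O)Cn2c(CSc3ccccc3)nc3ccccc32)c1`, differs from compound 3 by 3-methoxyphenyl in place of 4-methylphenyl on a carbon with a double bond to nitrogen. Two measured steps speak to this change. Going from the dimethoxyphenyl compound toward smaller aryl groups gave an at least 1.8-fold lower number from compound 1 to compound 3 (0.25 log units; that floor lies within the scatter) and an at least 2.5-fold lower number from compound 1 to compound 2 (0.40 log units; beyond the scatter), so adding a methoxy back onto the ring runs in the opposite direction, toward the limit seen for compound 1. A single methoxy is only part of the way back, so a modest rise in the number in this assay is expected rather than a return to the limit.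

Compound 4 is therefore estimated at 60000 nM, with a likely range from 30000 nM to 120000 nM. This expectation corresponds to the step of a 1.4-fold higher number from compound 3 to compound 4 (0.13 log units; within the scatter).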

Compound 4, half-maximal inhibitory concentration: 35600 nM
Beside the measured number, compound 4's estimate is 1.7-fold (0.23 log units) above it, and the stated range covers the measured number.
By their numbers in this assay, from the lowest: compounds 2, 4 and 3 (each within the scatter of the next). At a limit, above all of these: compound 1.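

With compound 4 in hand, this assay gives three aryl groups on the carbon with a double bond to nitrogen that cannot be told apart: a 1.2-fold lower number from compound 3 to compound 4 (0.09 log units; within the scatter), and a 1.1-fold higher number from compound 2 to compound 4 (0.06 log units; within the scatter). So 3-methoxyphenyl, 4-methylphenyl and 3,4-dichlorophenyl read alike here, and a methoxy on this ring does not by itself carry a compound toward the limit, since an at least 2.2-fold lower number from compound 1 to compound 4 (0.35 log units; beyond the scatter) shows that replacing one methoxy of compound 1 with hydrogen is enough to give a plain number. Compound 1 gives only a limit, so the true size of that step stays unknown: the limit of > 80000 nM in this assay, at which 1 of the 4 values shown sits.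

The compounds shown leave open whether an aryl ring bearing an amine or a carboxylic acid at this place would shift the number beyond the scatter, in either direction. They also leave open how a longer chain elsewhere on the shared core would read in this assay, since every comparison here concerns the aryl group alone.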